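The compounds below may be only part of what the source reports. "The series", "measured", "known", "first", "only" and "open" are said of these compounds alone.

Compound 2 `O=C(Oc1ccc(-c2cncn2C2CCN(C(=O)c3ccc(Cl)c(C(F)(F)F)c3)CC2)cc1)c1ccccc1` carries a benzoyl group on an oxygen on an aromatic ring. In an assay on HEK293 cells for antagonist activity at P2X purinoceptor 7 (Homo sapiens), read by fluorescence, with a stated time of 2 h (a higher number here means a weaker inhibitor, a lower number a stronger inhibitor), compound 2 gives only a limit, > 10000 nM. Compound 1 `O=C(Oc1ccc(-c2cncn2C2CCN(C(=O)c3ccc(Cl)c(C(F)(F)F)c3)CC2)cc1)c1cccc2cnccc12`, with isoquinolin-5-yl in place of that phenyl, likewise gives only a limit in this assay, > 10000 nM. the limit of > 10000 nM in this assay, at which 2 of the 3 values shown sit, leaves the step that the two limits leave unreadable from compound 1 to compound 2 unreadable. Compound 3 `Nc1cccc(S(=O)(=O)Oc2ccc(-c3cncn3C3CCN(C(=O)c4ccc(Cl)c(C(F)(F)F)c4)CC3)cc2)c1` gives 565 nM in this assay, so the step of an at least 17-fold lower number from compound 2 to compound 3 (1.24 log units; beyond the scatter) is large, as is an at least 17-fold lower number from compound 1 to compound 3 (1.24 log units; beyond the scatter). Compound 4 `O=C(c1ccc(Cl)c(C(F)(F)F)c1)N1CCC(n2cncc2-c2ccc(OS(=O)(=O)c3cccc(Br)c3)cc2)CC1` differs from compound 2 in one place: (3-bromophenyl)sulfonyl in place of benzoyl on an oxygen on an aromatic ring. Within the data shown here, this is the same kind of exchange as that from compound 2 to compound 3; the (3-bromophenyl)sulfonyl group of compound 4 differs from the (3-aminophenyl)sulfonyl group of compound 3 only in its substituent, and no measured pair separates those two. Compound 4 is therefore expected to show the step of an at least 14-fold lower number from compound 2 to compound 4 (1.15 log units; beyond the scatter). For compound 4 the estimate is 700 nM, between 150 nM and 5000 nM.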

Compound 4, half-maximal inhibitory concentration: 896 nM
Compound 4: middle estimate off by 1.3-fold (0.11 log units), on the low side, within the range that was stated.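

With (3-bromophenyl)sulfonyl on an oxygen on an aromatic ring, the step is an at least 11-fold lower number from compound 2 to compound 4 (1.04 log units; beyond the scatter), and the wider exchange gives an at least 11-fold lower number from compound 1 to compound 4 (1.04 log units; beyond the scatter); both steps start from a limit of the assay. Bromo in place of amino on an aromatic carbon gives a 1.6-fold higher number from compound 3 to compound 4 (0.20 log units; within the scatter). The step away from the carbonyl-linked groups in this assay is therefore not confined to the amino compound, compound 3.

On these data alone, it remains open whether 3-bromobenzoyl or 3-aminobenzoyl would match these sulfonyl groups. Also open, as far as these compounds go, is how unsubstituted phenylsulfonyl, or a carboxylic acid on that ring, would read.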